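Changing the benzoyloxy end of compound 1

The compounds below may be only part of what the source reports. "The series", "measured", "known", "first", "only" and "open" are said of these compounds alone.

Among the measured compounds shown here, in a functional assay on MCF7 cells (Homo sapiens) for inhibition, read by XTT assay, with a stated time of 48 h (on this read-out higher numbers stand for weaker inhibition and lower numbers for stronger inhibition), compound 1 (`CCC(/C=C(\COC(=O)c1ccccc1)C(=O)c1ccc(OC)cc1)CC`) gives 28000 nM as the highest of three numbers so far, which makes it the weakest inhibitor of the three. The other two sit lower: compound 2 (`COc1ccc(C(=O)/C(=C/C2CCCCC2)COC(=O)c2ccccc2)cc1`) at 13700 nM and compound 3 (`COc1ccc(C(=O)/C(=C/c2ccccc2Cl)COC(=O)c2ccccc2)cc1`) at 9000 nM on the same scale. Replacing pentan-3-yl with cyclohexyl gives a 2.0-fold lower number from compound 1 to compound 2 (0.31 log units; beyond the scatter) and replacing it with 2-chlorophenyl gives a 3.1-fold lower number from compound 1 to compound 3 (0.49 log units; beyond the scatter) as modest steps. The remaining comparison shows a 1.5-fold lower number from compound 2 to compound 3 (0.18 log units; within the scatter) and so no real difference.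

Compound 4 (`CCC(/C=C(\CCOC(C)=O)C(=O)c1ccc(OC)cc1)CC`) changes a different place, with acetoxymethyl in place of benzoyloxy on a saturated chain carbon bound to a double-bonded chain carbon. For the measured compounds named here, none of the measured steps touches this place, so they show only that single changes elsewhere in compound 1 moved the number modestly. No step beyond the scatter is therefore expected, and the estimated change is a 1.1-fold higher number from compound 1 to compound 4 (0.03 log units; within the scatter) for now. In this assay compound 4 is expected at 30000 nM (estimated range 12000 nM to 75000 nM).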

Compound 4, half-maximal inhibitory concentration: > 100000 nM
Compound 4: only a limit was reported; the forecaster's own chance of this, stated with the estimate: 15%; middle value at least 3.3-fold (0.52 log units) away from the limit.
By their numbers in this assay, from the lowest: compounds 3 and 2 (each within the scatter of the next); then compound 1. At a limit, above all of these: compound 4.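

The earlier steps shown here all changed the group on the double-bonded chain carbon, so they said nothing about the benzoyloxy end of compound 1. In this assay, compound 4 gives only a limit of the assay and not a number: the limit of > 100000 nM in this assay, at which 1 of the 4 values shown sits. As far as these compounds go, exchanging benzoyloxy for the smaller, ring-free acetoxymethyl gives an at least 3.5-fold higher number from compound 1 to compound 4 (0.55 log units; beyond the scatter), which means weaker inhibition and shows that this position does not tolerate every change, although the full size of the step remains unknown.

The ring and the heavy-atom count change together in this single step, so the compounds shown cannot separate the loss of the aromatic ring from the loss of size. From the compounds shown here alone, it also remains open how a phenylacetoxy group, which would keep an aromatic ring, or an amine or a carboxylic acid at this place would fare.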